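Capping an Aromatic Amine and Watching Liver-Cell Toxicity

The compounds below may be only part of what the source reports. "The series", "measured", "known", "first", "only" and "open" are said of these compounds alone.

Compound 1 `Nc1ccc(CN2N=C(c3ccc(F)cc3)C3C=CC=CC3C2=O)cc1` carries a free amino group on its outer aromatic ring. In an ADME assay on Huh-7 cells (Homo sapiens) for cytotoxicity, read by MTT assay, with a stated time of 48 h (on this read-out higher numbers stand for lower toxicity in this test and lower numbers for higher toxicity in this test), compound 1 gives > 80000 nM, which is a limit of the assay rather than a number. All that is known of compound 1 here is the limit of > 80000 nM in this assay, at which 1 of the 3 values shown sits. Two related compounds give a sense of the neighbourhood: compound 2 `CC(c1ccc(N(CCCCN(C)C)C(=O)O)cc1)n1nc(-c2ccc(F)cc2)c2ccccc2c1=O` gives 15200 nM in this assay, and compound 3 `CN(C)CCCCN(C(=O)O)c1ccc(N2N=C(c3ccc(F)cc3)C3C=CC=CC3C2=O)cc1` gives 21800 nM, the two values lying within the usual scatter of each other. Compound 4 `CN(C)CCCC(=O)Nc1ccc(CN2N=C(c3ccc(F)cc3)C3C=CC=CC3C2=O)cc1` differs from compound 1 by (3-(dimethylamino)propyl)carbonyl in place of hydrogen on a nitrogen on an aromatic ring. Going by the values given here, no measured step of this kind exists, so the step from compound 1 to compound 4 an at least 2.2-fold lower number from compound 1 to compound 4 (0.35 log units; beyond the scatter) is expected to run toward lower numbers, beyond the scatter. Compound 4 is therefore estimated at 35000 nM in this assay, within a range from 15000 nM to 80000 nM.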

Compound 4, half-maximal cytotoxic concentration: 38200 nM
The estimate for compound 4 lay 1.1-fold (0.04 log units) below the measured number; measured number inside the range.
By their numbers in this assay, from the lowest: compounds 2, 3 and 4 (each within the scatter of the next, the first and the last beyond it). At a limit, above all of these: compound 1.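

Placing (3-(dimethylamino)propyl)carbonyl on the amino group gives the only measured step at this nitrogen: in this assay the change produces an at least 2.0-fold lower number from compound 1 to compound 4 (0.32 log units; beyond the scatter) and so moves toward higher toxicity in this test. The full size of the step cannot be read because compound 1 is known only as a limit: the limit of > 80000 nM in this assay, at which 1 of the 4 values shown sits.

Still open, as far as these compounds go, is whether a plain acetyl group on the same nitrogen would shift the number in the same direction, which would show whether the dimethylamino end of the chain matters. From the compounds shown here alone, a longer chain and a chain ending in a carboxylic acid also remain open.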